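Replacing a pyrrolidinylamino with an anilino group

The source may report more compounds than this note shows. Statements on the series, on what has been measured and on what is new or still open speak of the compounds shown alone.

This account concerns an assay on isolated protein for inhibition of tyrosine-protein kinase receptor UFO (Homo sapiens), with a stated time of 1.5 h (on this read-out lower numbers stand for stronger inhibition and higher numbers for weaker inhibition), and three measured compounds. Compound 1 `Cn1cc(-c2n[nH]c3ccc(-c4ccccc4)cc23)cn1` gives 620 nM. Compound 2 `Brc1cnn2cccnc12` gives 330000 nM. Compound 3 `Cn1cc(-c2n[nH]c3ccc(NC4CCNC4)cc23)cn1` gives 132000 nM, which places it second highest of the three numbers, nearer to compound 2 than to compound 1. For the measured compounds named here, the one step that runs between two measured compounds differing in a single place is a 210-fold higher number from compound 1 to compound 3 (2.33 log units; beyond the scatter), so exchanging a phenyl for a saturated amine-bearing ring at that position of the shared core went along with a much weaker result.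

Compound 4 `Cn1cc(-c2n[nH]c3ccc(Nc4ccccc4)cc23)cn1` is not yet measured. It differs from compound 3 by phenyl in place of pyrrolidin-3-yl on a nitrogen on an aromatic ring. The change thus brings back a phenyl ring, now held on the nitrogen rather than on the aromatic carbon itself, so that the group becomes anilino instead of (pyrrolidin-3-yl)amino. Going by the values given here, no measured pair shows exactly this exchange; the step from compound 1 to compound 3 bears on it only because it shows how far the phenyl-bearing and the pyrrolidinyl-bearing compounds lie apart. On that basis compound 4 is expected to sit well below compound 3 and above compound 1, a step of a 44-fold lower number from compound 3 to compound 4 (1.64 log units; beyond the scatter). The estimate for compound 4 is 3000 nM, within a range from 600 nM to 15000 nM.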

Compound 4, half-maximal inhibitory concentration: 580 nM
Compound 4: the middle estimate sits 5.2-fold (0.71 log units) above what was measured, and the stated range ends above it.
By their numbers in this assay, from the lowest: compounds 4 and 1 (each within the scatter of the next); then compound 3; then compound 2.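

In this assay, for the compounds shown here, putting phenyl in place of pyrrolidin-3-yl on the nitrogen gives a 230-fold lower number from compound 3 to compound 4 (2.36 log units; beyond the scatter) and so separates two things that the earlier compounds left joined: the nitrogen stays in compound 4, so its presence at this place on the shared core does not by itself go with the weak result of compound 3, and the group it carries makes the difference. Exchanging phenyl on the aromatic carbon for anilino gives a 1.1-fold lower number from compound 1 to compound 4 (0.03 log units; within the scatter) and lies within the scatter, so across this pair the phenyl ring gives an equivalent result whether it stands directly on the aromatic carbon or is held on the nitrogen. Nothing available here explains why the pyrrolidin-3-yl and phenyl groups on the nitrogen lie so far apart.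

Still open, as far as these compounds go, is whether the result holds only for an unsubstituted phenyl ring, or also for a cyclohexyl or pyridinyl ring on the nitrogen, or for a phenyl ring carrying a fluorine or a methoxy group. The compounds shown also leave open what a methyl group on that nitrogen, or an oxygen in its place, would do.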